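Swapping methyl for trifluoromethylphenyl on a triazene amide

The compounds below may be only part of what the source reports. "The series", "measured", "known", "first", "only" and "open" are said of these compounds alone.

Measured so far:
- compound 1 `CC(=O)Oc1ccc(/C=C/C(=O)N(/N=N/c2ccc(Cl)c(C(F)(F)F)c2)c2ccc(Cl)c(C(F)(F)F)c2)cc1OC(C)=O`: 43000 nM
- compound 2 `CC(=O)N(/N=N/c1ccc([N+](=O)[O-])cc1Cl)c1ccc([N+](=O)[O-])cc1Cl`: 630 nM

In a functional assay on HeLa cells (Homo sapiens) for cytotoxicity, read by MTT assay, with a stated time of 72 h (a lower number here means a stronger inhibitor, a higher number a weaker inhibitor), compound 2 gives 630 nM and holds the lowest number of the two; compound 1 gives 43000 nM, a gap beyond the usual scatter. Compound 3 `O=C(c1cccc(C(F)(F)F)c1)N(/N=N/c1ccc([N+](=O)[O-])cc1Cl)c1ccc([N+](=O)[O-])cc1Cl` differs from compound 2 by 3-(trifluoromethyl)phenyl in place of methyl on a carbonyl carbon. Going by the values given here, no comparable step between measured compounds exists here, so the direction is uncertain; a modest weakening seems most likely, within or just beyond the scatter. Compound 3 is therefore expected to give about 1000 nM, between 250 nM and 5000 nM, a step of a 1.6-fold higher number from compound 2 to compound 3 (0.20 log units; within the scatter) from compound 2 to compound 3.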

Compound 3, half-maximal inhibitory concentration: 1180 nM
Compound 3: middle estimate off by 1.2-fold (0.07 log units), on the low side; the range from low to high includes it.
By their numbers in this assay, from the lowest: compounds 2 and 3 (each within the scatter of the next); then compound 1.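

In this assay the exchange of methyl for 3-(trifluoromethyl)phenyl gives a 1.9-fold higher number from compound 2 to compound 3 (0.27 log units; within the scatter) and leaves the two compounds indistinguishable. A carbonyl carbon whose other neighbour is an amide-type nitrogen can therefore carry a ring-bearing group of 10 heavy atoms instead of 1 without a measurable loss of cytotoxicity. Nothing measured here gives a reason for this result. Open, from the compounds shown here alone, is whether an amine or a carboxylic acid on that ring, or a longer alkyl chain in its place, would be accepted equally well.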